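Half-Life Outlook for a Larger Amide on Compound 1

The source may hold more compounds than are shown below. What is called first, only, known or untested is meant among the compounds shown, and "the series" means these compounds.

Measured compounds:
compound 1 `CC(=O)Nc1ccc(-c2nn(C)/c(=N/C3CCCC(O)C3)s2)cc1` – 2.3 h
compound 2 `Cn1nc(-c2ccc(S(C)(=O)=O)cc2)s/c1=N\C1CCCC(O)C1` – 2 h; 2.5 h (2 entries)

Among the compounds with values here, in an in vivo ADME assay on the whole organism for pharmacokinetics, at a dose of 2.5 mg/kg by the oral route (on this read-out higher numbers stand for a longer-lived compound and lower numbers for a shorter-lived compound), compound 1 gives 2.3 h, one of only two numbers recorded here. Compound 2 is the other measured compound, and its repeat entries, (the several entries of compound 2 in this assay, 2 h; 2.5 h (2 entries)), show how closely duplicate runs of this assay agree. Within the data shown here, no step between measured compounds that differ in a single place is available, so there is no measured precedent for the change in question.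

Compound 3 `Cn1nc(-c2ccc(C(=O)NC(C)(C)CO)cc2)s/c1=N\C1CCCC(O)C1` has not yet been measured. It differs from compound 1 in one place: (1-(hydroxymethyl)-1-methylethyl)carbamoyl in place of acetamido on an aromatic carbon. Among the measured compounds shown here, with no measured step to lean on, the expected change in this assay is a 1.0-fold higher number from compound 1 to compound 3 (0.02 log units; within the scatter), which is none beyond the usual scatter. Compound 3 is therefore estimated at 2.4 h, within a range of 1.2 h to 4.8 h.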

Compound 3, half-life: 0.46 h
Compound 3: middle estimate off by 5.2-fold (0.72 log units), on the high side; measured number outside the range, below it.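

This aromatic carbon is not indifferent to the group it carries: in this assay, (1-(hydroxymethyl)-1-methylethyl)carbamoyl in place of acetamido gives a 5.0-fold lower number from compound 1 to compound 3 (0.70 log units; beyond the scatter). Within the data shown here, until now no single change at this place had a measured result, so this is the first sign that half-life responds to the group here. A step of this size stands well apart from the agreement between repeat runs of one compound: the several entries of compound 2 in this assay, 2 h; 2.5 h (2 entries)

A single step cannot tell which part of the new group matters: the hydroxymethyl, the branched carbon carrying it, or the carbonyl now bound directly to the ring. As far as these compounds go, a simple methyl amide or a carboxylic acid on the same carbon could help separate these parts, and whether any group here can lengthen half-life beyond that of compound 1 remains open.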